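Aryl variation on the shared core, all at the limit

The source may report more compounds than this note shows. Statements on the series, on what has been measured and on what is new or still open speak of the compounds shown alone.

compound 1 `COc1ccc(/C=C2\CC[C@H]3C(C)(C)CCC[C@]3(C)[C@H]2CCC(C)CC(=O)O)cc1`: in a functional assay on K562 cells (Homo sapiens) for cytotoxicity, read by MTT assay, with a stated time of 24 h (on this read-out higher numbers stand for weaker inhibition and lower numbers for stronger inhibition), compound 1 gives > 200000 nM, a limit of the assay.
compound 2 `Cc1ccc(/C=C2\CC[C@H]3C(C)(C)CCC[C@]3(C)[C@H]2CCC(C)CC(=O)O)cc1`: in this assay compound 2 gives > 200000 nM, a limit of the assay.
compound 3 `COc1ccc(/C=C2\CC[C@H]3C(C)(C)CCC[C@]3(C)[C@H]2CCC(C)CC(=O)O)cc1OC`: in this assay compound 3 gives > 200000 nM, a limit of the assay.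

Compound 3 stands nowhere that can be placed: its result in this assay is a limit only, and the two other values shown are limits as well, so that the limit of > 200000 nM in this assay, at which 3 of the 3 values shown sit, describes the whole set. None of the steps among the measured compounds can be read: a step that the two limits leave unreadable from compound 1 to compound 2, a step that the two limits leave unreadable from compound 1 to compound 3 and a step that the two limits leave unreadable from compound 2 to compound 3 are each hidden by the limits on both sides, so no size and no direction is available from them.

Compound 4 `CC(CC[C@H]1/C(=C/c2ccc(F)cc2)CC[C@H]2C(C)(C)CCC[C@]12C)CC(=O)O` differs from compound 3 in one place: 4-fluorophenyl in place of 3,4-dimethoxyphenyl on a double-bonded chain carbon bound to a double-bonded ring carbon. Within the data shown here, the measured steps bear on this change only in that every aryl variation tried so far, methoxy, methyl and dimethoxy, has stayed beyond the limit in this assay; no step was readable, so nothing argues for a move beyond the scatter in either direction. The expected step that the limit leaves unreadable from compound 3 to compound 4 is therefore an estimate set at no change. Compound 4 is expected to give about 250000 nM in this assay, within a range of 80000 nM to 1000000 nM, most likely again reported as a limit.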

Compound 4, half-maximal inhibitory concentration: > 200000 nM
Compound 4 ended at the assay's limit (the forecaster's own chance of this, stated with the estimate: 85%); the middle value is on the limit's open side.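

Among these compounds, no step joining compound 4 to compound 1, compound 2 or compound 3 can be read in this assay, where the whole set rests at a limit of the assay: the limit of > 200000 nM in this assay, at which 4 of the 4 values shown sit. The compounds shown leave open how far each lies beyond that limit, and whether any aryl group on the shared core would give a measurable value in this assay.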